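The source may report more compounds than this note shows. Statements on the series, on what has been measured and on what is new or still open speak of the compounds shown alone.

Measured compounds in an assay on isolated protein for inhibition of tyrosine-protein kinase receptor UFO (Homo sapiens), with a stated time of 1.5 h; on this read-out higher numbers stand for weaker inhibition and lower numbers for stronger inhibition:

- compound 1, `Nc1ccc2c(Br)n[nH]c2c1`: > 770000 nM, a limit of the assay rather than a number
- compound 2, `Cn1cc(-c2n[nH]c3cc(-c4ccccc4)ccc23)cn1`: 12300 nM
- compound 3, `Cn1cc(-c2n[nH]c3ccc(-c4ccccc4)cc23)cn1`: 620 nM

Compound 2 stands at the higher of the two numbers that this assay has given; compound 3 sits well below it, by a gap that lies beyond the usual scatter, so the two differ only in where the phenyl sits on the shared core. For compound 1 the value is a limit, and nothing more than that can be said of it.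

The step under consideration goes from compound 2 to compound 4, `Cn1cc(-c2n[nH]c3cc(N)ccc23)cn1`, not yet measured in this assay. The change is amino in place of phenyl on an aromatic carbon. Among the measured compounds shown here, the phenyl that leaves is the only group on that side of the core of compound 2, so the step strips the core down to the amino alone.

Without a measured step of this kind in the set, the expectation rests on the two numbers and the limit alone. The step from compound 2 to compound 4 is expected to be a loss, larger than the scatter, as a 6.5-fold higher number from compound 2 to compound 4 (0.81 log units; beyond the scatter). For compound 4 the estimate in this assay is 80000 nM, with a range from 15000 nM to 400000 nM, and a real chance that only a limit is returned.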

Compound 4, half-maximal inhibitory concentration: 28800 nM
Beside the measured number, compound 4's estimate is 2.8-fold (0.44 log units) above it; measured number inside the range.
By their numbers in this assay, from the lowest: compound 3; then compound 2; then compound 4. At a limit, above all of these: compound 1.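

In this assay, a 2.3-fold higher number from compound 2 to compound 4 (0.37 log units; beyond the scatter) shows that a single amino can replace the whole phenyl on this aromatic carbon at only a modest loss, so the number at this place does not depend heavily on keeping that six-membered ring. The phenyl has so far been seen only to move on the shared core, and compound 3, with the phenyl at the other place, still holds the lowest number in the set at 620 nM. Compound 1, which has the same amino but a bromo in place of the methylpyrazole, returns no number, only a limit of the assay: the limit of > 770000 nM in this assay, at which 1 of the 4 values shown sits.

As far as these compounds go, whether the amino contributes anything itself remains open, as the core with a bare hydrogen at this place, or with a methyl, hydroxyl or acetamide there, would be needed to separate its effect from the loss of the phenyl. From the compounds shown here alone, it is also open whether an amino at the place occupied by the phenyl in compound 3 would give a similarly modest step from that lower number.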